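Tetrazolyl in Place of Carboxy on a Bombesin Receptor Agonist

This account rests on a few compounds, and the source may have more. Where it says the series, first, only, none or still open, it means among the compounds named here.

Measured compounds:
compound 1 `CCC(C)(C)Cc1c[nH]c(CCc2ccc(-c3ccccc3O)cc2)n1`: 34 nM
compound 2 `CCC(C)(C)Cc1c[nH]c(CCc2ccc(-c3ccccc3OCC(=O)O)cc2)n1`: "not determined" (no result reported)
compound 3 `CCC(C)(C)Cc1c[nH]c(CCc2ccc(N3CCCC[C@@H]3C(=O)O)cc2)n1`: 12 nM

In a functional assay for agonist activity at Bombesin receptor subtype-3 (Mus musculus) (a lower number here means that less compound is needed, a higher number that more compound is needed for the effect), compound 3 gives the lower of the two numbers, and the step between them, a 2.8-fold lower number from compound 1 to compound 3 (0.45 log units; beyond the scatter), lies beyond the scatter. Compound 2 has no number in this assay. Compound 4 `CCC(C)(C)Cc1c[nH]c(CCc2ccc(N3CCCC[C@@H]3c3nnn[nH]3)cc2)n1` differs from compound 3 by 1H-tetrazol-5-yl in place of carboxy on a saturated ring carbon. Among the measured compounds shown here, no measured step exchanges the carboxy group itself; the single measured step, a 2.8-fold lower number from compound 1 to compound 3 (0.45 log units; beyond the scatter), swaps a whole substituent and so bears only loosely on this change. The step from compound 3 to compound 4 is therefore expected to be small, within the scatter or just beyond it, a 1.7-fold higher number from compound 3 to compound 4 (0.22 log units; within the scatter). Compound 4 is estimated at 20 nM, with a range from 5 nM to 80 nM.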

Compound 4, half-maximal effective concentration: 16 nM
The estimate for compound 4 lay 1.3-fold (0.10 log units) above the measured number; the range from low to high includes it.
By their numbers in this assay, from the lowest: compounds 3 and 4 (each within the scatter of the next); then compound 1.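

In this assay, putting 1H-tetrazol-5-yl in place of carboxy on this saturated ring carbon gives a 1.3-fold higher number from compound 3 to compound 4 (0.12 log units; within the scatter). The position therefore accepts the five-membered aromatic ring in place of carboxy, and a free carboxy group is not needed for a number of this size in the series. The data at hand offer no explanation for why the two groups read alike.

On these data alone, it remains open whether a primary amide, a hydroxymethyl group or an acyl sulfonamide at this ring carbon would fit equally well. As far as these compounds go, the effect of the opposite configuration at this carbon also remains open.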